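The source may report more compounds than this note shows. Statements on the series, on what has been measured and on what is new or still open speak of the compounds shown alone.

Measured so far, all in an assay on isolated protein for inhibition of DNA topoisomerase 1 (Homo sapiens), with a stated time of 30 min, tested at 100 uM; a lower number here means a weaker effect, a higher number a stronger effect of the compound at the concentration tested:
Compound 1 `Oc1ccc(-c2cc(-c3ccccc3)nc(-c3ccccc3Cl)c2)cc1` gives 13.6% in this assay.
Compound 2 `Oc1cccc(-c2cc(-c3cccnc3)nc(-c3ccccc3Cl)c2)c1` gives 0% in this assay.
Compound 3 `Oc1cccc(-c2cc(-c3ccccc3)nc(-c3ccc(Cl)cc3)c2)c1` gives 7.1% in this assay.

Compound 3 stands second highest of the three numbers, yet its gap to compound 1 and its gap to compound 2 both lie within the scatter, so the three values cannot be ranked. Compound 4 `Oc1cccc(-c2cc(-c3ccccc3)nc(-c3ccccc3Cl)c2)c1` is compound 3 with its atoms joined differently: 2-chlorophenyl in place of 4-chlorophenyl on an aromatic carbon. Going by the values given here, no measured pair shows the effect of such a change on its own. Compounds 1 and 2 carry the 2-chlorophenyl group already and show no effect beyond the scatter, so the step expected from compound 3 to compound 4 in this assay is small, a number 0.9 percentage points higher from compound 3 to compound 4 (within the scatter), in no clear direction. Compound 4 is therefore expected to give 8% in this assay, within 0% to 20%.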

Compound 4, a percentage reported as inhibition, at one concentration (the size of the read-out at that concentration, not a potency): 3.2%
Beside the measured number, compound 4's estimate is 4.8 percentage points above it; measured number inside the range.
By their numbers in this assay, from the lowest: compounds 2, 4, 3 and 1 (each within the scatter of the next, the first and the last beyond it).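

In this assay, 2-chlorophenyl in place of 4-chlorophenyl gives a number 3.9 percentage points lower from compound 3 to compound 4 (within the scatter) and phenyl in place of pyridin-3-yl gives a number 3.2 percentage points higher from compound 2 to compound 4 (within the scatter) so neither swap can be told apart from the scatter. Going by these compounds alone, the only single change that clears the scatter is 3-hydroxyphenyl in place of 4-hydroxyphenyl, with a number 10.4 percentage points lower from compound 1 to compound 4 (beyond the scatter) as a modest step resting on one pair of compounds. Nothing measured here explains that step. From the compounds shown here alone, whether an amine or a carboxylic acid in place of the hydroxyl would shift the number stays open, and readings at one concentration say nothing about potency.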